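The source may hold more compounds than are shown below. What is called first, only, known or untested is meant among the compounds shown, and "the series" means these compounds.

Measured so far in a functional assay on L6 cells (Rattus norvegicus) for inhibition; a higher number here means a weaker inhibitor, a lower number a stronger inhibitor:
- compound 1 `CC(C)c1c(C(=O)N(C)Cc2ccccc2)nn(-c2ccc(F)cc2)c1CC[C@@H](O)C[C@@H](O)CC(=O)O` at 2870 nM
- compound 2 `CC(C)c1c(C(=O)N2CCC[C@H](c3ccccc3)C2)nn(-c2ccc(F)cc2)c1CC[C@@H](O)C[C@@H](O)CC(=O)O` at 310 nM
- compound 3 `CC(C)c1c(C(=O)N(C)Cc2ccccc2)nn(-c2ccc(F)cc2)c1OC[C@@H](O)C[C@@H](O)CC(=O)O` at 6720 nM

Compound 3 carries the highest number of the three. Compound 4 `Cc1ccc(CN(C)C(=O)c2nn(-c3ccc(F)cc3)c(OC[C@@H](O)C[C@@H](O)CC(=O)O)c2C(C)C)cc1` departs from it by a single change, methyl in place of hydrogen on an aromatic carbon with methyl in place of hydrogen on an aromatic carbon, para to a large group, so that benzyl becomes 4-methylbenzyl.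

Among the compounds with values here, no measured step covers so small a change. The nearest is the replacement of benzyl(methyl)amino by 3-phenylpiperidin-1-yl (a 9.3-fold lower number from compound 1 to compound 2 (0.97 log units; beyond the scatter)), a modest step for a much larger change in the same part of the structure. The other step (a 2.3-fold higher number from compound 1 to compound 3 (0.37 log units; beyond the scatter)) concerns the chain carrying the carboxy group and says little about the benzyl group.

A single methyl is therefore expected to shift the number in this assay by no more than the scatter, with a slight lean towards a lower number. The estimated step is a 1.3-fold lower number from compound 3 to compound 4 (0.13 log units; within the scatter) and stays within the scatter. For compound 4 the expected value is 5000 nM with an estimated range from 2000 nM to 12000 nM in this measurement.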

Compound 4, half-maximal inhibitory concentration: 1250 nM
The estimate for compound 4 lay 4.0-fold (0.60 log units) above the measured number, and the stated range ends above it.
By their numbers in this assay, from the lowest: compound 2; then compound 4; then compound 1; then compound 3.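

In this assay, methyl in place of hydrogen on an aromatic carbon, para to a large group, turns benzyl into 4-methylbenzyl and gives a 5.4-fold lower number from compound 3 to compound 4 (0.73 log units; beyond the scatter). Within the data shown here, the benzyl(methyl)amino part had so far been seen changing only as a whole, in a 9.3-fold lower number from compound 1 to compound 2 (0.97 log units; beyond the scatter), whereas this result shows that a single added carbon on the phenyl ring already moves the number beyond the scatter. Nothing available accounts for a step of this size from so small a change.

Among these compounds, the methyl is seen only with the (5-carboxy-2,4-dihydroxypentyl)oxy chain, so its effect with the 6-carboxy-3,5-dihydroxyhexyl chain of compound 1 remains open. Also open, as far as these compounds go, is whether a chlorine atom, an ethyl group or a methoxy group at the same place would lower the number as the methyl does.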